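Chloro in place of hydrogen on compound 1

This account rests on a few compounds, and the source may have more. Where it says the series, first, only, none or still open, it means among the compounds named here.

Compound 1 `Cc1[nH]c2ccc([N+](=O)[O-])cc2c1C1(c2c(C)[nH]c3ccc([N+](=O)[O-])cc23)C(=O)Nc2ccccc21`: 890 nM
Compound 2 `O=C1Nc2ccccc2C1(c1c(-c2ccccc2)[nH]c2ccccc12)c1c(-c2ccccc2)[nH]c2ccccc12`: 8910 nM

In a functional assay on A549 cells (Homo sapiens) for cytotoxicity, read by MTT assay, with a stated time of 48 h (a lower number here means a stronger inhibitor, a higher number a weaker inhibitor), compound 1 holds the lower of the two numbers, and its gap to compound 2 lies beyond the scatter. Among the measured compounds shown here, these two compounds offer no step that differs in one place. Compound 3 `Cc1[nH]c2ccc([N+](=O)[O-])cc2c1C1(c2c(C)[nH]c3ccc([N+](=O)[O-])cc23)C(=O)Nc2ccc(Cl)cc21` has chloro in place of hydrogen on an aromatic carbon of the core of compound 1 (chloro in place of hydrogen on an aromatic carbon). For the measured compounds named here, no measured step shows what this change does in this assay. The expected 1.3-fold lower number from compound 1 to compound 3 (0.10 log units; within the scatter) is small, towards a lower number, and possibly none beyond the scatter. For compound 3 the estimated value is 700 nM, with an expected range of 250 nM to 2000 nM.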

Compound 3, half-maximal inhibitory concentration: 69400 nM
Compound 3: middle estimate off by 99-fold (2.00 log units), on the low side, and the stated range ends below it.
By their numbers in this assay, from the lowest: compound 1; then compound 2; then compound 3.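

In this assay, the aromatic carbon of the core that is para to a fused ring proves highly sensitive: a single chloro in place of hydrogen gives a 78-fold higher number from compound 1 to compound 3 (1.89 log units; beyond the scatter). Among the compounds shown here, this is the first measured step at this position, and it shows that one added heavy atom there can weaken the compound sharply. Nothing at hand accounts for the size of this step.

As far as these compounds go, whether a fluoro, a methoxy or an amine on the same carbon would weaken the compound as chloro does remains open. From the compounds shown here alone, it is also open whether chloro has the same effect on compound 2.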